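Cytotoxicity notes on halogen-substituted phenyl variants of one core

The source may hold more compounds than are shown below. What is called first, only, known or untested is meant among the compounds shown, and "the series" means these compounds.

Measured so far:
compound 1 `COc1cc(-c2nnc(SCc3ccc([N+](=O)[O-])cc3)o2)ccc1O`: 688000 nM
compound 2 `COc1cc(-c2nnc(SCc3ccccc3F)o2)ccc1O`: 474000 nM
compound 3 `COc1cc(-c2nnc(SCc3ccccc3Cl)o2)ccc1O`: 564000 nM

In an ADME assay on cells (Mus musculus, strain BALB/c) for cytotoxicity, read by MTT assay, with a stated time of 24 h (on this read-out higher numbers stand for lower toxicity in this test and lower numbers for higher toxicity in this test), compound 3 stands second highest of the three numbers. Its nearest neighbour is compound 2; the step of a 1.2-fold higher number from compound 2 to compound 3 (0.08 log units; within the scatter) is within the scatter. Its furthest is compound 1, which gives 688000 nM, while compound 3 gives 564000 nM; this gap too is within the scatter. All three numbers therefore sit together, with no order that can be read from them.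

Compound 4 `COc1cc(-c2nnc(SCc3ccc(Br)cc3)o2)ccc1O` is not yet measured. The change from compound 3 is 4-bromophenyl in place of 2-chlorophenyl on a saturated chain carbon bound to a sulfur. Going by the values given here, the only measured step that bears on it is the halogen exchange on an aromatic carbon, a 1.2-fold higher number from compound 2 to compound 3 (0.08 log units; within the scatter), which was within the scatter. Among the compounds with values here, no measured step moves a substituent from one ring position to another, so that part of the change has no precedent here. On this basis no step beyond the scatter is expected in this assay.

Compound 4 is expected to give 600000 nM, with a range of 300000 nM to 1200000 nM. That estimate means a 1.1-fold higher number from compound 3 to compound 4 (0.03 log units; within the scatter), a step expected to stay within the scatter.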

Compound 4, half-maximal cytotoxic concentration: 455000 nM
Compound 4: middle estimate off by 1.3-fold (0.12 log units), on the high side, and the stated range covers the measured number.
By their numbers in this assay, from the lowest: compounds 4, 2, 3 and 1 (each within the scatter of the next).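

In this assay, 4-bromophenyl on a saturated chain carbon bound to a sulfur does not separate from 2-chlorophenyl (a 1.2-fold lower number from compound 3 to compound 4 (0.09 log units; within the scatter)) or from 2-fluorophenyl (a 1.0-fold lower number from compound 2 to compound 4 (0.02 log units; within the scatter)), so this change, which alters both the halogen and its ring position, gives no step beyond the scatter. The series also now holds a step away from the nitro group, bromo in place of nitro on an aromatic carbon (a 1.5-fold lower number from compound 1 to compound 4 (0.18 log units; within the scatter)), and this too stays within the scatter. No supporting data bear on why these numbers sit together.

The compounds shown leave the halogen and its ring position tied together in the change to 4-bromophenyl. From the compounds shown here alone, whether an amine or a carboxylic acid on the phenyl ring, or a longer chain at the sulfur, would give a step beyond the scatter remains open.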